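Swapping a thiazole for a furan on the shared core

A few compounds are considered here, and "the series" means these few. Any claim that something is new, unique, unknown or untested is made for them only; others in the source may bear on it.

Compound 1 `O=C(Nc1ccc(-c2cscn2)cc1)C1CCCN(Cc2ccc(F)c(F)c2)C1` gives 880 nM
Compound 2 `O=C(Nc1ccc(-c2nccs2)cc1)C1CCCN(Cc2ccc(F)c(F)c2)C1` gives 240 nM

In a functional assay on A-375 cells (Homo sapiens) for antiproliferative activity (a higher number here means a weaker inhibitor, a lower number a stronger inhibitor), compound 2 stands lowest of the two at 240 nM so far. Compound 3 `O=C(Nc1ccc(-c2ccoc2)cc1)C1CCCN(Cc2ccc(F)c(F)c2)C1` carries furan-3-yl in place of 1,3-thiazol-2-yl on an aromatic carbon. Among the compounds with values here, the one measured step bearing on this is modest: a 3.7-fold lower number from compound 1 to compound 2 (0.56 log units; beyond the scatter) (beyond the scatter) for 1,3-thiazol-2-yl in place of 1,3-thiazol-4-yl. No furan has been measured, so a step of similar size is expected, upward from compound 2 at 240 nM toward a higher number. The expected change is a 2.3-fold higher number from compound 2 to compound 3 (0.36 log units; beyond the scatter) as an estimate. Compound 3 is estimated at 550 nM with an expected range from 170 nM to 1800 nM here.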

Compound 3, half-maximal inhibitory concentration: 1290 nM
The estimate for compound 3 lay 2.3-fold (0.37 log units) below the measured number, within the range that was stated.
By their numbers in this assay, from the lowest: compound 2; then compounds 1 and 3 (each within the scatter of the next).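

In this assay, furan-3-yl in place of 1,3-thiazol-2-yl gives a 5.4-fold higher number from compound 2 to compound 3 (0.73 log units; beyond the scatter), so a second ring type at this position also falls short of compound 2. Furan-3-yl in place of 1,3-thiazol-4-yl gives a 1.5-fold higher number from compound 1 to compound 3 (0.17 log units; within the scatter), so among these three five-membered aromatic rings only 1,3-thiazol-2-yl stands apart. Nothing available explains this difference. The compounds shown leave open whether an amine or a carboxylic acid on this aromatic carbon would match compound 2.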